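Swapping One Aryl Group for Another on the Triazole

This account rests on a few compounds, and the source may have more. Where it says the series, first, only, none or still open, it means among the compounds named here.

In a functional assay on HeLa cells (Homo sapiens) for inhibition, read by MTT assay, with a stated time of 72 h (a lower number here means a stronger inhibitor, a higher number a weaker inhibitor), compound 3 `O=c1cc(Cn2cc(-c3cc(F)cc(F)c3)nn2)c2ccc(O)cc2o1` gives 27600 nM, the lowest of the two numbers available, with compound 2 `O=c1cc(Cn2cc(CCc3ccccc3)nn2)c2ccc(O)cc2o1` nearby at 35100 nM so that a 1.3-fold lower number from compound 2 to compound 3 (0.10 log units; within the scatter). For compound 1 `O=c1cc(Cn2cc(CCCCO)nn2)c2ccc(O)cc2o1` the result is a limit of the assay, > 100000 nM. Starting from compound 1, an at least 2.8-fold lower number from compound 1 to compound 2 (0.45 log units; beyond the scatter) and an at least 3.6-fold lower number from compound 1 to compound 3 (0.55 log units; beyond the scatter). Compound 4 `O=c1cc(Cn2cc(-c3ccc(Br)cc3)nn2)c2ccc(O)cc2o1` carries 4-bromophenyl in place of 3,5-difluorophenyl on an aromatic carbon. For the measured compounds named here, the one measured step that likewise exchanges one aryl group for another, a 1.3-fold lower number from compound 2 to compound 3 (0.10 log units; within the scatter), stayed within the scatter, whereas the clear gains appeared only where a hydroxyalkyl chain of compound 1 gave way to an aromatic group. For the aryl-for-aryl swap the expectation is therefore a 1.1-fold lower number from compound 3 to compound 4 (0.04 log units; within the scatter), nothing beyond the scatter. Compound 4 is estimated at 25000 nM, within 8000 nM to 80000 nM.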

Compound 4, half-maximal inhibitory concentration: 40200 nM
Compound 4: the middle estimate sits 1.6-fold (0.21 log units) below what was measured; measured number inside the range.
By their numbers in this assay, from the lowest: compounds 3, 2 and 4 (each within the scatter of the next). At a limit, above all of these: compound 1.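

At this ring carbon, 4-bromophenyl in place of 3,5-difluorophenyl gives a 1.5-fold higher number from compound 3 to compound 4 (0.16 log units; within the scatter), and in place of phenethyl it gives a 1.1-fold higher number from compound 2 to compound 4 (0.06 log units; within the scatter), so these three groups read alike. In place of 4-hydroxybutyl it gives an at least 2.4-fold lower number from compound 1 to compound 4 (0.39 log units; beyond the scatter), which extends to one more aromatic group the gain seen on leaving that chain. That step has only a minimum size, because compound 1 stands at a limit: the limit of > 100000 nM in this assay, at which 1 of the 4 values shown sits.

The compounds shown leave open whether an amine, a carboxylic acid or a pyridine ring here would move the number beyond the scatter of these three groups.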